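Removing a Bromo Group: Two Steps of the Same Kind

The source may report more compounds than this note shows. Statements on the series, on what has been measured and on what is new or still open speak of the compounds shown alone.

Compound 1, `COc1cc(/C=N/Nc2nc(-c3ccc(F)c(F)c3)cs2)cc(Br)c1OC`: 22400 nM
Compound 2, `COc1cc(/C=N/Nc2nc(-c3ccc(F)c(F)c3)cs2)c(Br)c(Br)c1OC`: 49700 nM
Compound 3, `Fc1ccc(/C=N/Nc2nc(-c3ccc(Br)cc3)cs2)cc1F`: for compound 3 the result is a limit of the assay, > 100000 nM

All three were tested in a functional assay on HepG2 cells (Homo sapiens) for inhibition, read by MTT assay, with a stated time of 48 h; on this read-out higher numbers stand for weaker inhibition and lower numbers for stronger inhibition. Compound 2 and compound 1 differ in one place, (hydrogen in place of bromo on an aromatic carbon), and that change gave a 2.2-fold lower number from compound 2 to compound 1 (0.35 log units; beyond the scatter), so removing the bromo group made inhibition somewhat stronger there. How the core of compound 3 differs from the core of compound 2 is not broken down here. Compound 3 sits at the limit (the limit of > 100000 nM in this assay, at which 1 of the 3 values shown sits), so only a boundary and not a number is known for it.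

Compound 4, `Fc1ccc(/C=N/Nc2nc(-c3ccccc3)cs2)cc1F`, has not yet been measured. It differs from compound 3 in the same kind of change, (hydrogen in place of bromo on an aromatic carbon). The surroundings are not the same: in the earlier step the carbon was ortho to a bromo group, ortho to a large group, meta to a methoxy group and para to a methoxy group, whereas here it is para to a large group.

For compound 4 a step of roughly a number no higher from compound 3 to compound 4 (the limit leaves the size open) is expected, resting on the modest size of a 2.2-fold lower number from compound 2 to compound 1 (0.35 log units; beyond the scatter). Since compound 3 gave only a limit, compound 4 is expected to give about 100000 nM in this assay, likely between 40000 nM and 300000 nM, with a real chance that only a limit is reported again.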

Compound 4, half-maximal inhibitory concentration: > 100000 nM
Compound 4 ended at the assay's limit; the forecaster's own chance of this, stated with the estimate: 60%; the middle value lies on the limit itself.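

In this assay, compound 3 and compound 4 both ended at a limit rather than at a number, so no step can be read for the change from 4-bromophenyl to phenyl: the limit of > 100000 nM in this assay, at which 2 of the 4 values shown sit.

The compounds shown leave open whether removing this bromo group changes inhibition at all, and whether it would make inhibition somewhat stronger, as it did between compound 2 and compound 1.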